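Swapping diethylamino for a silicon-bearing group

The source may report more compounds than this note shows. Statements on the series, on what has been measured and on what is new or still open speak of the compounds shown alone.

Compound 1 `CC(C)=CCC[C@]1(C)/C=C/[C@@H](OC(=O)C=C(C)C)[C@](C)(O)/C=C/C(=O)/C(C=O)=C\C1`: 12600 nM
Compound 2 `CC(C)=CCC[C@]1(C)/C=C/[C@@H](OC(=O)C=C(C)C)[C@](C)(O)/C=C/C(=O)/C(C(=O)O)=C\C1`: 16100 nM
Compound 3 `CCN(CC)C/C1=C/C[C@](C)(CCC=C(C)C)/C=C/[C@@H](OC(=O)C=C(C)C)[C@](C)(O)/C=C/C1=O`: 130 nM

In a functional assay on MCF7 cells (Homo sapiens) for antiproliferative activity, read by MTT assay, with a stated time of 48 h (a higher number here means a weaker inhibitor, a lower number a stronger inhibitor), compound 3 has the lowest number of the three, which makes it the strongest inhibitor so far. Its lead is large on both sides: a 97-fold lower number from compound 1 to compound 3 (1.99 log units; beyond the scatter) and a 120-fold lower number from compound 2 to compound 3 (2.09 log units; beyond the scatter). The other two cannot be told apart, with a 1.3-fold higher number from compound 1 to compound 2 (0.11 log units; within the scatter).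

Compound 4 `CC(C)=CCC[C@]1(C)/C=C/[C@@H](OC(=O)C=C(C)C)[C@](C)(O)/C=C/C(=O)/C(C[Si](C)(C)C(C)(C)C)=C\C1` keeps the core of compound 3 and changes one group: a group of 7 heavy atoms (6 carbon, 1 silicon; no ring) in place of a group of 5 heavy atoms (4 carbon, 1 nitrogen; no ring), on a saturated chain carbon bound to a double-bonded ring carbon. The diethylamino group leaves and a group of carbon and silicon enters, on a saturated chain carbon bound to a double-bonded ring carbon.

For the measured compounds named here, no measured compound carries this new group, so the evidence is indirect. Of the three measured compounds, only compound 3 has diethylamino, and the two without it both sit far higher. Those two large steps therefore suggest that losing diethylamino will raise the number. The rise may be somewhat smaller, since the entering group is neither formyl nor carboxy. The expected change in this assay is a 31-fold higher number from compound 3 to compound 4 (1.49 log units; beyond the scatter). For compound 4 the estimated value is 4000 nM, with an expected range from 500 nM to 20000 nM.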

Compound 4, half-maximal inhibitory concentration: 6040 nM
The estimate for compound 4 lay 1.5-fold (0.18 log units) below the measured number, and the stated range covers the measured number.
By their numbers in this assay, from the lowest: compound 3; then compound 4; then compounds 1 and 2 (each within the scatter of the next).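

The new group keeps the saturated chain carbon on the double-bonded ring carbon and gives up diethylamino, and a 46-fold higher number from compound 3 to compound 4 (1.67 log units; beyond the scatter) in this assay shows that this chain carbon alone does not preserve the strong result. A small gain over the formyl and carboxy compounds does remain, with a 2.1-fold lower number from compound 1 to compound 4 (0.32 log units; beyond the scatter) and a 2.7-fold lower number from compound 2 to compound 4 (0.43 log units; beyond the scatter) as modest steps, so most of the advantage disappears in this set once diethylamino is replaced, but not all of it. Nothing in the data shown explains why this exchange has such an effect.

For the compounds shown here, with only one nitrogen-free group to compare, the nitrogen itself cannot be separated from the rest of the diethylamino group. Going by these compounds, it remains open whether a smaller amine such as dimethylamino, a ring amine such as piperidine, or an all-carbon group shaped like diethylamino would stay close to compound 3 or fall toward compound 4 in this assay.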